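This account rests on a few compounds, and the source may have more. Where it says the series, first, only, none or still open, it means among the compounds named here.

Measured compounds:
- compound 1, `CCCNC(=C\C(=O)/C=C/c1ccc(O)c(OC)c1)/C=C/c1ccc(O)c(OC)c1`, with 78%
- compound 2, `CCC(C)NC(=C\C(=O)/C=C/c1ccc(O)c(OC)c1)/C=C/c1ccc(O)c(OC)c1`, with 85%
- compound 3, `C=CCNC(=C\C(=O)/C=C/c1ccc(O)c(OC)c1)/C=C/c1ccc(O)c(OC)c1`, with 124%

In a functional assay on EA.hy 926 cells (Homo sapiens), read by fluorescence, tested at 1 uM (on this read-out lower numbers stand for a weaker effect and higher numbers for a stronger effect at the one concentration tested), compound 3 stands highest of the three measured compounds; compound 2 lies nearest, as a number 39 percentage points higher from compound 2 to compound 3 (beyond the scatter) shows, and compound 1 furthest, as a number 46 percentage points higher from compound 1 to compound 3 (beyond the scatter) shows. Both gaps are beyond the scatter, so compound 3 is the most active of the three.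

Compound 4, `COc1cc(/C=C/C(=O)/C=C(/C=C/c2ccc(O)c(OC)c2)NCC(C)C)ccc1O`, is reached from compound 3 by isopropyl in place of vinyl on a saturated chain carbon bound to an amine nitrogen. Within the data shown here, two measured steps bear on this change. The step from compound 1 to compound 3 put vinyl in place of ethyl at the same position, and a number 46 percentage points higher from compound 1 to compound 3 (beyond the scatter) was large; the step from compound 2 to compound 3 exchanged a saturated branched chain for allyl, and a number 39 percentage points higher from compound 2 to compound 3 (beyond the scatter) was likewise large. The change to compound 4 runs the other way, replacing the unsaturated group with a saturated branched one, so a step downward of comparable size is expected. The step from compound 1 to compound 2, a number 7 percentage points higher from compound 1 to compound 2 (within the scatter), suggests that the shape of the saturated chain matters little. Compound 4 is therefore expected to give 85%, in the range 65% to 110%, which means an estimated step of a number 39 percentage points lower from compound 3 to compound 4 (beyond the scatter).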

Compound 4, a percentage reported as activity, at one concentration (the size of the read-out at that concentration, not a potency): 83%
Beside the measured number, compound 4's estimate is 2 percentage points above it, and the stated range covers the measured number.
By their numbers in this assay, from the lowest: compounds 1, 4 and 2 (each within the scatter of the next); then compound 3.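

In this assay the change from allyl to isobutyl gave a number 41 percentage points lower from compound 3 to compound 4 (beyond the scatter) and so showed that the high number of compound 3 did not carry over to a third saturated chain, here one branched further out on the amine nitrogen. The isobutyl compound joined the other two saturated chains, with a number 2 percentage points lower from compound 2 to compound 4 (within the scatter) for isobutyl in place of sec-butyl and a number 5 percentage points higher from compound 1 to compound 4 (within the scatter) for methyl in place of hydrogen on a saturated chain carbon bound to two saturated chain carbons, so neither of these changes in chain shape moved the number beyond the scatter. Among these four compounds, allyl alone stood apart, and compound 3 remained the most active.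

The compounds shown leave open whether the higher number needs the double bond of allyl specifically, or whether a propargyl group, a cyclopropylmethyl group, a benzyl group or a longer unsaturated chain on the amine nitrogen would reach it as well. Nothing available here accounts for the gap between allyl and the saturated chains.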